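The source may hold more compounds than are shown below. What is called first, only, known or untested is meant among the compounds shown, and "the series" means these compounds.

Measured compounds in a physicochemical assay for lipophilicity, at pH 7.4; a lower number here means a more polar compound, a higher number a more lipophilic compound:
Compound 1 `Cc1cc(C(=O)O)nn1C(C)c1cc(Cl)ccc1OCc1ccccc1` gives 1.
Compound 2 `Cc1cc(C(=O)Nc2ccccn2)nn1Cc1cc(Cl)ccc1OCc1ccccc1` gives > 3.7, which is a limit of the assay and not a number.
Compound 3 `Cc1cc(C(=O)NN2CCCCC2)nn1Cc1cc(Cl)ccc1OCC(C)C` gives 3.3.

Compound 2 thus stands at the upper edge of what has been measured here, without an exact figure: the limit of > 3.7 in this assay, at which 1 of the 3 values shown sits. Compound 4 `Cc1cc(NC(=O)C2CCOCC2)nn1Cc1cc(Cl)ccc1OCc1ccccc1` has not yet been measured. It differs from compound 2 in one place: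
((oxan-4-yl)carbonyl)amino in place of (pyridin-2-yl)carbamoyl on an aromatic carbon
Within the data shown here, no step between two measured compounds with a change of this kind is available, so the expectation rests on judgement alone. A moderate downward step is expected in this assay, estimated as a number at least 0.60 log units lower from compound 2 to compound 4 (beyond the scatter). Compound 4 is expected to come out near 3.1, between 2.5 and 3.7.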

Compound 4, distribution coefficient: > 3.7
Compound 4 was reported as a limit (the forecaster's own chance of this, stated with the estimate: 10%); middle value at least 0.60 log units away from the limit.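

Among these compounds, compound 2 and compound 4 both stand at a limit of the assay and not at a number, so no step between them can be read: the limit of > 3.7 in this assay, at which 2 of the 4 values shown sit.
As far as these compounds go, what stays open is how far ((oxan-4-yl)carbonyl)amino in place of (pyridin-2-yl)carbamoyl moves the result in this assay, if at all.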